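Swapping Chloro for Acetyl on the Phenyl Ring

The compounds below may be only part of what the source reports. "The series", "measured", "known", "first", "only" and "open" are said of these compounds alone.

Compound 1 `COc1cc(-c2ccnc3cc(-c4ccc(Cl)cc4)nn23)cc(OC)c1OC` is the weakest inhibitor of the three measured compounds: in a functional assay on B16-F0 cells (Mus musculus) for inhibition, read by CCK-8 assay, with a stated time of 48 h (on this read-out lower numbers stand for stronger inhibition and higher numbers for weaker inhibition), compound 1 gives 4090 nM, the highest of the three numbers. Compound 2 `COc1cc(-c2ccnc3cc(-c4ccc5cc[nH]c5c4)nn23)cc(OC)c1OC` gives 55 nM and compound 3 `COc1cc(-c2ccnc3cc(-c4cn(C)c5ccccc45)nn23)cc(OC)c1OC` gives 185 nM. Both steps away from compound 1 are large, a 74-fold lower number from compound 1 to compound 2 (1.87 log units; beyond the scatter) and a 22-fold lower number from compound 1 to compound 3 (1.34 log units; beyond the scatter), while between the two indolyl compounds a 3.4-fold higher number from compound 2 to compound 3 (0.53 log units; beyond the scatter).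

Compound 4 `COc1cc(-c2ccnc3cc(-c4ccc(C(C)=O)cc4)nn23)cc(OC)c1OC` differs from compound 1 at a single point: acetyl in place of chloro on an aromatic carbon. The measured steps replace the whole 4-chlorophenyl with an indolyl ring system, so they bear only loosely on a change that keeps the 4-chlorophenyl framework and turns it into 4-acetylphenyl. Within the data shown here, no measured pair shows what one group in place of another on that ring does. The expectation is therefore a step within the scatter or only modestly beyond it, in either direction. Compound 4 is estimated at 3000 nM, with a range from 800 nM to 12000 nM, which corresponds to an expected 1.4-fold lower number from compound 1 to compound 4 (0.13 log units; within the scatter).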

Compound 4, half-maximal inhibitory concentration: 3930 nM
Beside the measured number, compound 4's estimate is 1.3-fold (0.12 log units) below it; the range from low to high includes it.
By their numbers in this assay, from the lowest: compound 2; then compound 3; then compounds 4 and 1 (each within the scatter of the next).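

In this assay, among these compounds, the first exchange of one group on this phenyl ring gives a 1.0-fold lower number from compound 1 to compound 4 (0.02 log units; within the scatter) and so shows that chloro and acetyl, with its hydrogen-bond acceptor, read alike at this place. The distance to the indolyl compounds stays large, with a 21-fold higher number from compound 3 to compound 4 (1.33 log units; beyond the scatter) and with a 71-fold higher number from compound 2 to compound 4 (1.85 log units; beyond the scatter) and compound 4 therefore sits with compound 1 on the far side of that gap. Among the compounds shown, the large steps go with the change of the whole ring system and not with the choice between these two groups, and no supporting evidence accounts for this.

Two groups at one position do not make a trend. On these data alone, whether an amine, a carboxylic acid or a longer chain on this phenyl ring would read like chloro and acetyl, or would approach the indolyl compounds, stays open.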